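A few compounds are considered here, and "the series" means these few. Any claim that something is new, unique, unknown or untested is made for them only; others in the source may bear on it.

Working notes on the series. Compound 1 `OC1CCCCC1n1cc(CN2CCN(c3ccccc3)CC2)nn1` carries a hydrogen on the oxygen on a saturated carbon of the shared core, and in an assay on nucleic acid for inhibition of Nucleic Acid, read by fluorescence, tested at 100 uM (on this read-out lower numbers stand for less inhibition and higher numbers for more inhibition at the one concentration tested (going by the name of the read-out)), compound 1 gives 47%. Among the measured compounds shown here, compound 2 `O=C(OC1CCCCC1n1cc(CN2CCN(c3ccccc3)CC2)nn1)c1ccccc1` carries a benzoyl group on that oxygen instead; in this assay compound 2 gives 21%, the lowest of the two numbers measured so far, the only other being compound 1, and the step of a number 26 percentage points lower from compound 1 to compound 2 (beyond the scatter) describes the drop. Compound 3 `O=C(COc1ccccc1)OC1CCCCC1n1cc(CN2CCN(c3ccccc3)CC2)nn1` is not yet measured and differs from compound 2 by phenoxymethyl in place of phenyl on a carbonyl carbon. For the measured compounds named here, the one measured step exchanges hydrogen for benzoyl on the oxygen and so concerns the presence of the ester, not an exchange within its acyl part; no measured pair bears directly on the change from compound 2 to compound 3, and no direction can be read from the data. The expected step of a number 1 percentage points higher from compound 2 to compound 3 (within the scatter) is therefore taken as one that stays within the scatter. Compound 3 is estimated at 22% in this assay, with an expected range from 5% to 40%.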

Compound 3, a percentage reported as inhibition, at one concentration (the size of the read-out at that concentration, not a potency): 37%
Estimate against measurement, compound 3: 15 percentage points below; the range from low to high includes it.
By their numbers in this assay, from the lowest: compound 2; then compounds 3 and 1 (each within the scatter of the next).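

In this assay, the acyl part of the ester matters, not only its presence: phenoxymethyl in place of phenyl on a carbonyl carbon gives a number 16 percentage points higher from compound 2 to compound 3 (beyond the scatter), the first measured change within that part. The ester as such therefore does not set the read-out at the level of compound 2, since (phenoxymethyl)carbonyl in place of hydrogen on the same oxygen gives a number 10 percentage points lower from compound 1 to compound 3 (within the scatter), while benzoyl there gives a number 26 percentage points lower from compound 1 to compound 2 (beyond the scatter). No measurement on hand speaks to what lies behind these differences.

The shown compounds do not separate the ether oxygen of phenoxymethyl from the added length between the carbonyl carbon and the aromatic ring, and a benzyl group on that carbonyl carbon would tell these two apart. Also open, as far as these compounds go, is how the read-out responds when the acyl part ends in something other than a phenyl ring, such as an amine or a carboxylic acid, and whether an amide in place of the ester linkage keeps the picture seen with compound 2 and compound 3.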